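Chloro to Hydrogen on the Triazole's Phenyl Ring

This account rests on a few compounds, and the source may have more. Where it says the series, first, only, none or still open, it means among the compounds named here.

Three compounds built on a shared core have been examined in an ADME assay on HeLa cells (Homo sapiens) for cytotoxicity, read by MTT assay; a lower number here means a stronger inhibitor, a higher number a weaker inhibitor. Compound 1 `COc1ccc(C[C@H]2COC(=O)[C@@H]2Cc2ccc(OCc3cn(Cc4ccc(Cl)cc4)nn3)c(OC)c2)cc1OC` gives 242000 nM. In this assay compound 2 `COc1ccc(C[C@H]2COC(=O)[C@@H]2Cc2ccc(OC(=O)CCC(=O)N3CCCCC3)c(OC)c2)cc1OC` gives 128000 nM. Compound 3 `COc1ccc(C[C@H]2COC(=O)[C@@H]2Cc2ccc(OCc3cn(-c4ccc(Cl)cc4)nn3)c(OC)c2)cc1OC` gives 279000 nM, the highest of the three numbers; its nearest neighbour is compound 1, a gap within the scatter, while compound 2 lies furthest away, a gap beyond the scatter. Going by the values given here, the single step between compounds that differ in one place, a 1.2-fold higher number from compound 1 to compound 3 (0.06 log units; within the scatter), stayed within the scatter.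

Compound 4 `COc1ccc(C[C@H]2COC(=O)[C@@H]2Cc2ccc(OCc3cn(-c4ccccc4)nn3)c(OC)c2)cc1OC` differs from compound 3 by hydrogen in place of chloro on an aromatic carbon. Among the compounds with values here, no measured step addresses this exchange of a chloro for a hydrogen: the one step on record, a 1.2-fold higher number from compound 1 to compound 3 (0.06 log units; within the scatter), concerns the link between the triazole nitrogen and its aryl group rather than a substituent on that ring, and it changed little. With no evidence of a large effect from small changes at this end of the molecule, compound 4 is expected to show no step beyond the scatter, a 1.1-fold lower number from compound 3 to compound 4 (0.05 log units; within the scatter). Compound 4 is therefore estimated at 250000 nM, with a range from 120000 nM to 520000 nM.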

Compound 4, half-maximal inhibitory concentration: 124000 nM
The estimate for compound 4 lay 2.0-fold (0.30 log units) above the measured number, within the range that was stated.
By their numbers in this assay, from the lowest: compounds 4, 2, 1 and 3 (each within the scatter of the next, the first and the last beyond it).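

In this assay, taking the chloro off the 4-chlorophenyl group, an aromatic carbon para to a large group, gives a 2.3-fold lower number from compound 3 to compound 4 (0.35 log units; beyond the scatter) and so produces a modest change beyond the scatter, whereas the earlier change of link at this end, a 1.2-fold higher number from compound 1 to compound 3 (0.06 log units; within the scatter), stayed within it. Yet the change from 4-chlorobenzyl to phenyl, a 2.0-fold lower number from compound 1 to compound 4 (0.29 log units; within the scatter) and thus within the scatter, does not separate compound 4 from compound 1, and the exchange of the whole group on the oxygen, a 1.0-fold lower number from compound 2 to compound 4 (0.01 log units; within the scatter) and likewise within the scatter, does not separate it from compound 2, so only the pair of compound 3 and compound 4 marks a clear effect of this single atom. Nothing at hand explains why the chloro counts at this position.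

The compounds shown leave open whether taking the chloro off the 4-chlorobenzyl group of compound 1 would give a step of similar size. They also leave open whether fluoro, bromo, methyl or methoxy at the same place on the phenyl ring would follow chloro or hydrogen.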